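Piperazine sulfonamide series: benzyl for aryl on the ring nitrogen

A few compounds are considered here, and "the series" means these few. Any claim that something is new, unique, unknown or untested is made for them only; others in the source may bear on it.

Three compounds have numbers in an assay on CHO cells for displacement of a labelled ligand from adenosine receptor A2b (Homo sapiens), read by scintillation counting, with a stated time of 75 min, in the presence of a further agent that is not named here; a lower number here means a stronger inhibitor, a higher number a weaker inhibitor. Compound 1 `CCCn1c(=O)[nH]c2nc(-c3ccc(S(=O)(=O)N(C)C)cc3)[nH]c2c1=O`, bearing a dimethyl sulfonamide, gives 18.6 nM. Compound 2 `CCCn1c(=O)[nH]c2nc(-c3ccc(S(=O)(=O)N4CCN(c5ccccc5Br)CC4)cc3)[nH]c2c1=O`, in which the sulfonamide nitrogen is part of a piperazine carrying a 2-bromophenyl, gives 0.137 nM in this assay. Compound 3 `CCCn1c(=O)c2[nH]c(-c3ccc(S(=O)(=O)N4CCN(c5ccc(Cl)cc5)CC4)cc3)nc2n(C)c1=O`, a piperazine carrying a 4-chlorophenyl on a core that is methylated at one ring nitrogen, gives 1.91 nM in this assay. Compound 2 has the lowest number of the three; compound 3 is nearest and compound 1 furthest, both gaps beyond the scatter.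

Compound 4 `CCCn1c(=O)[nH]c2nc(-c3ccc(S(=O)(=O)N4CCN(Cc5ccc(Br)cc5)CC4)cc3)[nH]c2c1=O` is not yet measured. Its difference from compound 2 is counted as 4-bromobenzyl in place of 2-bromophenyl on an amine nitrogen in a ring. Among the measured compounds shown here, no measured pair in the set shows what a benzyl in place of an aryl on this ring nitrogen does, so the size of the step cannot be read from the data. The step of an 8.8-fold higher number from compound 2 to compound 4 (0.94 log units; beyond the scatter) is expected to be a loss of potency of modest size, beyond the scatter. Compound 4 is estimated at 1.2 nM, with a range from 0.2 nM to 7 nM.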

Compound 4, inhibition constant: 0.153 nM
Compound 4: the middle estimate sits 7.8-fold (0.89 log units) above what was measured, outside the stated range (below it).
By their numbers in this assay, from the lowest: compounds 2 and 4 (each within the scatter of the next); then compound 3; then compound 1.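

In this assay, among the compounds shown here, 4-bromobenzyl in place of 2-bromophenyl on the amine nitrogen in the ring gives a 1.1-fold higher number from compound 2 to compound 4 (0.05 log units; within the scatter), the first direct reading at this position. The sub-nanomolar numbers therefore do not depend on the aryl group being attached directly to this nitrogen: the benzyl and aryl forms cannot be told apart here. No measurement shown explains why the two groups read alike.

The change moves the bromine and adds the benzyl carbon together, so a flat step could reflect either no effect from both or two effects that offset each other; 2-bromobenzyl or 4-bromophenyl on the same core would separate them. As far as these compounds go, whether this position also accepts an unsubstituted benzyl, or a benzyl carrying an amine or a carboxylic acid, remains open.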